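The compounds below may be only part of what the source reports. "The series", "measured", "known", "first", "only" and "open" are said of these compounds alone.

Three compounds on the shared core have numbers in a functional assay on SW-620 cells (Homo sapiens) for cytotoxicity, read by MTT assay, with stated times of 4 h and 72 h, tested at 2 uM; a lower number here means a stronger inhibitor, a higher number a weaker inhibitor: compound 1 (`COc1ccc(/C=C/C(=O)c2ccc(Nc3cc(C)nc4nc(SCc5nc6ccccc6[nH]5)nn34)cc2)cc1F`) gives 140 nM, compound 2 (`Cc1cc(Nc2ccc(C(=O)/C=C/c3ccc(F)cc3)cc2)n2nc(SCc3nc4ccccc4[nH]3)nc2n1`) gives 85 nM, and compound 3 (`Cc1ccc(/C=C/C(=O)c2ccc(Nc3cc(C)nc4nc(SCc5nc6ccccc6[nH]5)nn34)cc2)cc1`) gives 1520 nM. Compound 3 has the highest number of the three, and both steps to it lie beyond the scatter: an 11-fold higher number from compound 1 to compound 3 (1.04 log units; beyond the scatter) and an 18-fold higher number from compound 2 to compound 3 (1.25 log units; beyond the scatter). By contrast, a 1.6-fold lower number from compound 1 to compound 2 (0.22 log units; within the scatter) stays within the scatter.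

Compound 4 (`Cc1cc(Nc2ccc(C(=O)/C=C/c3ccccc3)cc2)n2nc(SCc3nc4ccccc4[nH]3)nc2n1`) differs from compound 3 by hydrogen in place of methyl on an aromatic carbon. Going by the values given here, no measured step makes this exact change. The nearest is an 18-fold higher number from compound 2 to compound 3 (1.25 log units; beyond the scatter), with methyl in place of fluoro on an aromatic carbon, and an 11-fold higher number from compound 1 to compound 3 (1.04 log units; beyond the scatter) also bears on it. The data do not show whether hydrogen will track fluoro, so a lower number in this assay is expected, but a smaller step than those two. The expected step is a 3.6-fold lower number from compound 3 to compound 4 (0.56 log units; beyond the scatter). The estimate for compound 4 is 420 nM, with an expected range of 110 nM to 1500 nM.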

Compound 4, half-maximal inhibitory concentration: 130 nM
The estimate for compound 4 lay 3.2-fold (0.51 log units) above the measured number; the range from low to high includes it.
By their numbers in this assay, from the lowest: compounds 2, 4 and 1 (each within the scatter of the next); then compound 3.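

In this assay, a 12-fold lower number from compound 3 to compound 4 (1.07 log units; beyond the scatter) ties the high number of compound 3 to the methyl on the 4-methylphenyl group, since the unsubstituted phenyl does not share it. With a 1.5-fold higher number from compound 2 to compound 4 (0.18 log units; within the scatter) and a 1.1-fold lower number from compound 1 to compound 4 (0.03 log units; within the scatter), both within the scatter, the phenyl, 4-fluorophenyl and 3-fluoro-4-methoxyphenyl groups cannot be told apart here, so neither fluoro nor methoxy is needed for a number in this range, and methyl alone stands out among the four compounds. No measurement here accounts for the effect of this methyl.

From the compounds shown here alone, it remains open whether chloro, ethyl or an amine at this position, para to a large group, would follow methyl or hydrogen. Also open, going by these compounds, is whether a methyl elsewhere on this ring would carry the same cost.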